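This account rests on a few compounds, and the source may have more. Where it says the series, first, only, none or still open, it means among the compounds named here.

Measured so far: compound 1 `COC(=O)c1ccc2ccc(C(=O)c3ccc(C(F)(F)F)cc3)c-2cc1` with -47.4%, and compound 2 `COC(=O)Cc1ccc2ccc(C(=O)c3ccccc3)c-2cc1` with -4.3%.

In an assay on cells for displacement of a labelled ligand from Orexin receptor type 2 (Homo sapiens), read by scintillation counting, with stated times of 10 min and 90 min, tested at 10 uM (on this read-out higher numbers stand for more inhibition at the one concentration tested (going by the name of the read-out) and lower numbers for less inhibition), compound 2 stands highest of the two numbers; its nearest neighbour, compound 1, lies lower by a gap beyond the scatter. For the measured compounds named here, compounds 1 and 2 differ in more than one place, so no single step between them is counted, and the two values only show that they sit far apart.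

Compound 3 `COC(=O)Cc1ccc2ccc(C(=O)c3ccc(C(F)(F)F)cc3)c-2cc1` is the next compound. From compound 2 it differs by one change: trifluoromethyl in place of hydrogen on an aromatic carbon, on an aromatic carbon of a six-membered aromatic ring of carbon only, para to a large group. Going by the values given here, nothing among the measured compounds isolates this change, so the direction of the step in this assay is open. He expects a small step from compound 2 to compound 3 of a number 15.7 percentage points lower from compound 2 to compound 3 (beyond the scatter), towards less inhibition. Compound 3 is therefore estimated to give -20%, within -55% to 15%.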

Compound 3, a percentage reported as inhibition, at one concentration (the size of the read-out at that concentration, not a potency): 1%
The estimate for compound 3 lay 21 percentage points below the measured number; measured number inside the range.
By their numbers in this assay, from the lowest: compound 1; then compounds 2 and 3 (each within the scatter of the next).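

In this assay, trifluoromethyl in place of hydrogen on an aromatic carbon, para to a large group, gives a number 5.3 percentage points higher from compound 2 to compound 3 (within the scatter) and so leaves the number at this position unchanged within the scatter. The other single change, (methoxycarbonyl)methyl in place of methoxycarbonyl on an aromatic carbon, gives a number 48.4 percentage points higher from compound 1 to compound 3 (beyond the scatter) with trifluoromethyl present in both compounds, so the wide gap seen earlier now attaches to this change and not to the trifluoromethyl position. No measurement on hand gives a reason for either step.

The compounds shown leave open whether the change from methoxycarbonyl to (methoxycarbonyl)methyl gives a step of similar size when hydrogen stands in place of trifluoromethyl. They also leave open how a carboxylic acid, an amide or a longer chain would read at that place, or a chlorine atom in place of trifluoromethyl.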